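A few compounds are considered here, and "the series" means these few. Any claim that something is new, unique, unknown or untested is made for them only; others in the source may bear on it.

Of the compounds shown here, three have been measured in an assay on CHO cells for displacement of a labelled ligand from adenosine receptor A3 (Homo sapiens), read by scintillation counting, with a stated time of 60 min; on this read-out lower numbers stand for stronger inhibition and higher numbers for weaker inhibition. Compound 1, `O=C(c1ccco1)N(C(=O)c1ccco1)c1nc(-c2ccccc2)nc2cn(-c3ccccc3)nc12`, gives 75 nM in this assay. Compound 2, `Cc1nc(N(C(=O)c2ccccc2)C(=O)c2ccccc2)c2nn(-c3ccccc3)cc2n1`, gives 33 nM. Compound 3, `Cc1nc(NC(=O)c2cccnc2)c2nn(-c3ccccc3)cc2n1`, gives 5.3 nM and so stands at the lowest number of the three, meaning the strongest inhibition seen here; its nearest neighbour is compound 2, and its steps to both compound 2 and compound 1 lie beyond the usual scatter, so it is the most potent of the measured set.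

The next compound, compound 4, `Cc1nc(NC(=O)c2ccncc2)c2nn(-c3ccccc3)cc2n1`, has not yet been measured. It keeps every atom of compound 3 but joins them differently: pyridin-4-yl in place of pyridin-3-yl on a carbonyl carbon. The carbonyl carbon that carries the ring is attached, on its other side, to an amide-type nitrogen, so only the point at which the ring is joined has moved.

Among the measured compounds shown here, no measured pair in this set shows what such a shift of attachment does in this assay. With nothing to go on but the structures, the expectation is a small step, most likely within the scatter, with a slight lean toward a higher number. Compound 4 is therefore estimated at 9 nM, within a range of 3 nM to 30 nM. That estimate amounts to an expected step of a 1.7-fold higher number from compound 3 to compound 4 (0.23 log units; within the scatter).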

Compound 4, inhibition constant: 5.2 nM
Compound 4: the middle estimate sits 1.7-fold (0.24 log units) above what was measured, within the range that was stated.
By their numbers in this assay, from the lowest: compounds 4 and 3 (each within the scatter of the next); then compound 2; then compound 1.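

Moving the point at which the ring is joined gives a step that lies within the scatter in this assay (a 1.0-fold lower number from compound 3 to compound 4 (0.01 log units; within the scatter)), so compound 3 and compound 4 cannot be told apart on this read-out. Among the compounds shown here, this is the first pair in the set that differs in only one place, and it gives the first direct reading of this position: on a carbonyl carbon attached to an amide-type nitrogen, pyridin-3-yl and pyridin-4-yl serve equally well in this measurement, even though the same atoms are joined differently. Nothing else measured here bears on why the two match, so the result stands as an observation without an explanation.

The pair covers only two ways of joining one ring, so it says nothing about pyridin-2-yl at this place, or about a ring carrying an added group such as methoxy or an amine. Compound 1 and compound 2 differ from compound 3 in more than one place, so they cannot show whether the ring nitrogen itself matters for the strength of binding.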